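The source may hold more compounds than are shown below. What is called first, only, known or untested is meant among the compounds shown, and "the series" means these compounds.

In a functional assay on the whole organism (Tail, strain ICR) with Mus musculus as the target, in the tail flick test, with a stated time of 30 min, at a dose of 25 umol/kg by the oral route (on this read-out lower numbers stand for a weaker effect and higher numbers for a stronger effect at the one dose given), compound 3 `CC(C)C[C@H](NC(=O)CN(c1nc(Cl)nc2[nH]cnc12)C1CC1)C(=O)OCc1ccccc1` gives 33.9%, the largest of the three numbers, though compound 1 `NCCCC[C@H](NC(=O)CN(c1nc(Cl)nc2[nH]cnc12)C1CC1)C(=O)O`, which gives 31.2%, lies within the scatter of it, while compound 2 `CSCC[C@H](NC(=O)CN(c1nc(Cl)nc2[nH]cnc12)C1CC1)C(=O)O` gives 20.4%, beyond the scatter. Going by the values given here, the only measured step, a number 10.8 percentage points lower from compound 1 to compound 2 (beyond the scatter), concerns the side chain. Compound 4 `CC(C)C[C@H](NC(=O)CN(c1nc(Cl)nc2[nH]cnc12)C1CC1)C(=O)O` differs from compound 3 at a different place: hydrogen in place of benzyl on an oxygen next to a carbonyl group. Among the compounds with values here, no measured step bears on this change, so the data give no size and no direction for it. The step from compound 3 to compound 4 is expected to be a number 3.9 percentage points lower from compound 3 to compound 4 (within the scatter), within the scatter. The estimate for compound 4 is 30%, with a range from 12% to 46%.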

Compound 4, a percentage reported as activity, at one dose (the size of the read-out at that dose, not a potency): 23.4%
Compound 4: the middle estimate sits 6.6 percentage points above what was measured; the range from low to high includes it.
By their numbers in this assay, from the lowest: compounds 2, 4, 1 and 3 (each within the scatter of the next, the first and the last beyond it).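

In this assay, going by these compounds alone, the change from benzyloxycarbonyl to carboxy now has a measured size and direction, a number 10.5 percentage points lower from compound 3 to compound 4 (beyond the scatter), the first evidence that the group on this oxygen affects the read-out. With the carboxy group kept, the side chain gives a number 3 percentage points higher from compound 2 to compound 4 (within the scatter) and a number 7.8 percentage points lower from compound 1 to compound 4 (within the scatter), so isopropyl cannot be separated from either other side chain. Nothing available explains the effect of losing benzyl.

Going by these compounds, whether methyl or ethyl on this oxygen would behave like benzyl or like hydrogen remains open. So does whether benzyl has the same effect with the side chains of compound 1 and compound 2.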